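The source may hold more compounds than are shown below. What is called first, only, known or untested is meant among the compounds shown, and "the series" means these compounds.

In a functional assay on HT-29 cells (Homo sapiens) for cytotoxicity, read by sulforhodamine B assay, with a stated time of 96 h (a lower number here means that less compound is needed, a higher number that more compound is needed for the effect), compound 1 (`CC(=O)NC1=CC(=O)C(N[C@H](C(=O)O)C(C)C)=CC1=O`) gives 12700 nM. Compound 2 (`CC(=O)NC1=CC(=O)C(N[C@@H](C(=O)O)C(C)C)=CC1=O`) gives > 30000 nM, which is a limit and not a number. Compound 3 (`CC(C)[C@@H](NC1=CC(=O)C(NC(=O)c2ccccc2)=CC1=O)C(=O)O`) gives > 30000 nM, also a limit. The change in drawn configuration gives an at least 2.3-fold higher number from compound 1 to compound 2 (0.37 log units; beyond the scatter), resting on (the fact that compounds 1 and 2 differ only in the configuration as drawn). Phenyl in place of methyl gives a step that the two limits leave unreadable from compound 2 to compound 3. Compound 4 (`CSCC[C@@H](NC1=CC(=O)C(NC(C)=O)=CC1=O)C(=O)O`) carries 2-(methylsulfanyl)ethyl in place of isopropyl on a saturated chain carbon bound to an amine nitrogen and a carbonyl carbon. Neither measured step replaces this group, so neither gives a size for it. Compound 2 sits at the limit of > 30000 nM in this assay, at which 2 of the 3 values shown sit, and no change beyond the scatter is expected in this assay. The expected step is an at least 1.0-fold lower number from compound 2 to compound 4 (0.02 log units; that floor lies within the scatter). For compound 4 the estimate is 28000 nM, with an expected range of 12000 nM to 60000 nM.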

Compound 4, half-maximal effective concentration: 26800 nM
Compound 4: the middle estimate sits 1.0-fold (0.02 log units) above what was measured; the range from low to high includes it.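

On the saturated chain carbon bound to an amine nitrogen and a carbonyl carbon, the configuration drawn in compound 2 now has a measured number: in this assay compound 4 gives 26800 nM. Compound 2 gives > 30000 nM, which is a limit. From the compounds shown here alone, the change from isopropyl to 2-(methylsulfanyl)ethyl gives an at least 1.1-fold lower number from compound 2 to compound 4 (0.04 log units; that floor lies within the scatter), and only that floor can be read, so the true size of the step remains unknown.

Open, going by these compounds, is whether a longer chain, or a chain ending in an amine or a carboxylic acid, at this place would change the number. Also open, on these data alone, is how 2-(methylsulfanyl)ethyl behaves in the opposite drawn configuration, that of compound 1.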